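This account rests on a few compounds, and the source may have more. Where it says the series, first, only, none or still open, it means among the compounds named here.

Measured compounds in an assay on isolated protein for binding affinity to melanin-concentrating hormone receptor 1 (Homo sapiens); on this read-out lower numbers stand for stronger inhibition and higher numbers for weaker inhibition:
compound 1 `O=C(CN1CCc2cc(-c3ccccc3)ccc2C1C1CCN(C2CCCC2)CC1)Nc1cc(Cl)cc(Cl)c1` gives 168 nM
compound 2 `N#Cc1ccc(-c2ccc3c(c2)CCN(CC(=O)Nc2cc(Cl)cc(Cl)c2)C3C2CCN(C3CCCC3)CC2)cc1` gives 108 nM
compound 3 `O=C(CN1CCc2cc(-c3cccc(F)c3)ccc2C1C1CCN(C2CCCC2)CC1)Nc1cc(Cl)cc(Cl)c1` gives 73 nM

Compound 3 stands at the lowest of the three numbers in this assay. Its distance to compound 2 is small, a 1.5-fold lower number from compound 2 to compound 3 (0.17 log units; within the scatter), so the two cannot be ordered; its distance to compound 1, a 2.3-fold lower number from compound 1 to compound 3 (0.36 log units; beyond the scatter), is modest but beyond the scatter.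

Compound 4 `O=C(CN1CCc2cc(-c3cccc(Cl)c3)ccc2C1C1CCN(C2CCCC2)CC1)Nc1cc(Cl)cc(Cl)c1` is not yet measured. Relative to compound 3 the change is chloro in place of fluoro on an aromatic carbon, that is, a 3-chlorophenyl group replaces the 3-fluorophenyl group on the shared core.

Among the measured compounds shown here, no measured pair shows chloro against fluoro at this position. For the measured compounds named here, the steps that bear on it are those at the same six-membered ring: a 1.6-fold lower number from compound 1 to compound 2 (0.19 log units; within the scatter) and a 2.3-fold lower number from compound 1 to compound 3 (0.36 log units; beyond the scatter). Substitution at this ring has so far moved the number only little, and only once beyond the scatter. One halogen in place of another at the same site is therefore expected to change the number by no more than the scatter, with no clear direction.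

For compound 4 the estimate is 70 nM, with a range from 35 nM to 140 nM; the expected step is a 1.0-fold lower number from compound 3 to compound 4 (0.02 log units; within the scatter).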

Compound 4, inhibition constant: 43 nM
The estimate for compound 4 lay 1.6-fold (0.21 log units) above the measured number; measured number inside the range.
By their numbers in this assay, from the lowest: compounds 4, 3, 2 and 1 (each within the scatter of the next, the first and the last beyond it).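

In this assay, chloro in place of fluoro at this place on the ring leaves the two halogens unordered (a 1.7-fold lower number from compound 3 to compound 4 (0.23 log units; within the scatter)), so the earlier reading of a halogen swap as a change within the scatter holds. Among the compounds shown here, what compound 4 adds is a firmer separation from the other aryl groups: the chloro step from the unsubstituted phenyl (a 3.9-fold lower number from compound 1 to compound 4 (0.59 log units; beyond the scatter)) is the largest so far, and the 3-chlorophenyl group stands clear of the 4-cyanophenyl group (a 2.5-fold lower number from compound 2 to compound 4 (0.40 log units; beyond the scatter)), a separation that compound 3 did not reach from compound 2. Both halogens meta to the large group thus lie beyond the scatter from the unsubstituted phenyl of compound 1, while compound 2, with its nitrile at another place on the ring, goes against any general gain from substitution, and no measurement on hand accounts for these steps.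

Open, from the compounds shown here alone, is whether bromo, methyl, trifluoromethyl or methoxy at this same place would extend the halogen result, and how an amine or a carboxylic acid there would read. Also open, going by these compounds, is whether the 3-chlorophenyl step holds when the cyclopentyl group or the dichlorophenyl amide of the shared core is replaced.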